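From phenyl to 4-methoxyphenyl in an antiproliferative series

The source may report more compounds than this note shows. Statements on the series, on what has been measured and on what is new or still open speak of the compounds shown alone.

Compound 1 `COc1ccc(Nc2nc(N)c(C(=O)c3ccccc3)s2)cc1` gives 850 nM
Compound 2 `COc1ccc(Nc2nc(N)c(C(=O)c3ccc(OC)c(OC)c3)s2)cc1` gives 38 nM
Compound 3 `COc1cccc(C(=O)c2sc(Nc3ccccc3)nc2N)c1` gives 7600 nM

All three numbers come from a functional assay on L1210 cells (Mus musculus) for antiproliferative activity, read by cell counting, with a stated time of 2 days; on this read-out lower numbers stand for stronger inhibition and higher numbers for weaker inhibition. Among them, compound 3 has the highest number, 7600 nM, and its distance to each of the other two lies beyond the scatter. Compound 4 `COc1ccc(Nc2nc(N)c(C(=O)c3cccc(OC)c3)s2)cc1` differs from compound 3 by one change, methoxy in place of hydrogen on an aromatic carbon, para to a large group, so that phenyl becomes 4-methoxyphenyl. Among the measured compounds shown here, no measured pair isolates this change. Still, 4-methoxyphenyl is present in compound 1 at 850 nM and in compound 2 at 38 nM, although these two also differ from compound 3 elsewhere. A large drop beyond the scatter is therefore expected, with the estimated step being a 25-fold lower number from compound 3 to compound 4 (1.40 log units; beyond the scatter). The value expected for compound 4 is 300 nM, with an estimated range of 70 nM to 1300 nM.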

Compound 4, half-maximal inhibitory concentration: 35 nM
The estimate for compound 4 lay 8.6-fold (0.93 log units) above the measured number, outside the stated range (below it).
By their numbers in this assay, from the lowest: compounds 4 and 2 (each within the scatter of the next); then compound 1; then compound 3.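

In this assay, among the compounds shown here, one pair now isolates this change for the first time: phenyl becoming 4-methoxyphenyl gives a 220-fold lower number from compound 3 to compound 4 (2.34 log units; beyond the scatter), so this single methoxy on its own accounts for a large step. A methoxy on the other aromatic ring also counts for much, with a 24-fold lower number from compound 1 to compound 4 (1.39 log units; beyond the scatter), while one methoxy more or less on that ring makes no difference beyond the scatter, with a 1.1-fold lower number from compound 2 to compound 4 (0.04 log units; within the scatter).

From the compounds shown here alone, whether a hydroxy group, an ethoxy group or a chlorine atom in place of the 4-methoxy group would keep this step remains open. Nothing given here explains the size of the step.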